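Working notes on compounds 1 to 3

The source may hold more compounds than are shown below. What is called first, only, known or untested is meant among the compounds shown, and "the series" means these compounds.

Measured in a functional assay on K562 cells (Homo sapiens) for antiproliferative activity, read by MTT assay, with a stated time of 72 h; on this read-out higher numbers stand for weaker inhibition and lower numbers for stronger inhibition:
compound 1, `COc1cc(C(=O)c2sc3ccccc3c2-c2ccccc2)cc(OC)c1OC`: 2100 nM
compound 2, `COc1ccc(-c2c(C(=O)c3cc(OC)c(OC)c(OC)c3)sc3ccccc23)cc1`: 1700 nM

Going by the values given here, compound 2 holds the lowest of the two numbers so far, but the step of a 1.2-fold lower number from compound 1 to compound 2 (0.09 log units; within the scatter) is within the scatter, so compound 1 and compound 2 are not separated on these data. Compound 3, `COc1ccc(OC)c(-c2c(C(=O)c3cc(OC)c(OC)c(OC)c3)sc3ccccc23)c1`, has not yet been measured. It differs from compound 2 by 2,5-dimethoxyphenyl in place of 4-methoxyphenyl on an aromatic carbon. Among the compounds with values here, the only measured step, a 1.2-fold lower number from compound 1 to compound 2 (0.09 log units; within the scatter), also concerned methoxy substitution on this aromatic ring and stayed within the scatter; no measured step covers a second methoxy on the same ring, so the data give no direction. On that basis no step beyond the scatter is expected in this assay. Compound 3 is therefore estimated at 1800 nM, with a range of 700 nM to 5000 nM. The expected step is a 1.1-fold higher number from compound 2 to compound 3 (0.02 log units; within the scatter).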

Compound 3, half-maximal inhibitory concentration: > 10000 nM
Compound 3 gave a limit, no number; the forecaster's own chance of this, stated with the estimate: 5%; middle value at least 5.5-fold (0.74 log units) away from the limit.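

Compound 3 gives a limit of the assay, not a number, so the size of its steps is only bounded on one side: the limit of > 10000 nM in this assay, at which 1 of the 3 values shown sits. At this position, on an aromatic carbon of the five-membered aromatic ring, 2,5-dimethoxyphenyl in place of 4-methoxyphenyl gives an at least 5.8-fold higher number from compound 2 to compound 3 (0.76 log units; beyond the scatter), and 2,5-dimethoxyphenyl in place of phenyl gives an at least 4.7-fold higher number from compound 1 to compound 3 (0.67 log units; beyond the scatter). Going by these compounds alone, the earlier step, a 1.2-fold lower number from compound 1 to compound 2 (0.09 log units; within the scatter), separated nothing, so this is the first sign that this assay responds to what the aromatic group at this position carries.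

The compounds shown do not tell which of the methoxy groups of 2,5-dimethoxyphenyl accounts for the change, or how far beyond the limit compound 3 lies. They also leave open how a hydroxyl group or an amine on this aromatic ring would read.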